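The compounds below may be only part of what the source reports. "The series", "measured", "known", "first", "only" and "open" are said of these compounds alone.

In an ADME assay on Raji cells (Homo sapiens) for cytotoxicity, read by CellTiter-Glo, with a stated time of 72 h (a lower number here means that less compound is needed, a higher number that more compound is needed for the effect), compound 1 (`CC1=C2CC(C)(C)/C=C/C/C(C)=C\C3=C[C@H](C)C[C@]3(O2)C1=O`) gives 26000 nM. Compound 2 (`CC(=O)O[C@H]1/C=C/C(C)(C)CC2=C(C)C(=O)[C@]3(C[C@@H](C)C=C3/C=C\1C)O2`), which carries an acetoxy group in place of a hydrogen on a saturated ring carbon, gives 26000 nM. Compound 3 (`CC1=C2CC(C)(C)/C=C/[C@H](OC(=S)n3ccnc3)/C(C)=C\C3=C[C@H](C)C[C@]3(O2)C1=O`), which carries a larger thiocarbonyl-linked imidazole group at that same carbon, gives 26000 nM, so it stands level with the other two at the digits shown.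

The next compound, compound 4 (`CC1=C2CC(C)(C)/C=C/[C@H](OC(=S)Sc3ccccc3)/C(C)=C\C3=C[C@H](C)C[C@]3(O2)C1=O`), differs from compound 3 at one place: phenylsulfanyl in place of 1H-imidazol-1-yl on a thiocarbonyl carbon. In short, phenylsulfanyl stands in place of 1H-imidazol-1-yl on a thiocarbonyl carbon.

Among the measured compounds shown here, three measured steps bear on this change. The closest is no change at the digits printed from compound 2 to compound 3 (within the scatter), which also alters the group on that oxygen. The other two are no change at the digits printed from compound 1 to compound 2 (within the scatter) and no change at the digits printed from compound 1 to compound 3 (within the scatter). None of the three moved the value in this assay, though none of them tests a phenylsulfanyl group directly. On that evidence, no shift beyond the scatter is expected in either direction, and the expected step is no change at the digits printed from compound 3 to compound 4 (within the scatter). For compound 4 the estimated value is 26000 nM, with an expected range from 13000 nM to 40000 nM.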

Compound 4, half-maximal effective concentration: 26000 nM
Compound 4: middle estimate and measured number agree at the digits printed; measured number inside the range.
By their numbers in this assay, from the lowest: compounds 1, 2, 3 and 4 (each within the scatter of the next).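

In this assay, phenylsulfanyl is the only group among these compounds that brings a six-membered aromatic ring of carbon only to the thiocarbonyl carbon, and its exchange for 1H-imidazol-1-yl gives no change at the digits printed from compound 3 to compound 4 (within the scatter), so the nitrogen-bearing ring is not needed to keep the reading at this level in these two compounds. Set against the acetoxy group of compound 2, the whole phenylsulfanyl-bearing group gives no change at the digits printed from compound 2 to compound 4 (within the scatter), and set against the hydrogen atom of compound 1, it gives no change at the digits printed from compound 1 to compound 4 (within the scatter), which extends the flat reading to a group with a carbon-only aromatic ring and two sulfur atoms. No supporting measurement is available to explain why the reading stays the same across these changes.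

The compounds shown leave open whether an amine or a carboxylic acid in place of phenylsulfanyl on a thiocarbonyl carbon would move the value beyond the scatter. All four compounds share the core of compound 1, so they also leave open how any change to that core would read in this assay.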